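The source may hold more compounds than are shown below. What is called first, only, known or untested is meant among the compounds shown, and "the series" means these compounds.

Among the measured compounds shown here, compound 1 `Cc1nn(C)c(Oc2cccc(F)c2)c1/C=N\CCCCCOc1cc2oc(=O)cc(C)c2cc1Cl` and compound 2 `Cc1nn(C)c(Oc2cccc(Cl)c2)c1/C=N\CCCCCCOc1cc2oc(=O)cc(C)c2cc1Cl` share one core and differ in two places at once, so no single step can be drawn between them. In a functional assay on U-87MG ATCC cells for antiproliferative activity against U-87 MG (Homo sapiens), read by MTT assay, with a stated time of 72 h (a higher number here means a weaker inhibitor, a lower number a stronger inhibitor), compound 1 gives 9870 nM, and in this assay compound 2 gives 8460 nM. These two numbers lie within the scatter of each other, so neither compound can be called the stronger inhibitor; compound 2 simply sits alongside compound 1 at the weak end of what has been measured.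

Compound 3 `Cc1ccccc1Oc1c(/C=N\CCCCCCOc2cc3oc(=O)cc(C)c3cc2Cl)c(C)nn1C` carries one change from compound 2: 2-methylphenyl in place of 3-chlorophenyl on an oxygen on an aromatic ring. For the measured compounds named here, no measured pair shows what such an exchange does here. With only a scatter-wide spread to go on, the step is expected to stay within the scatter, with no clear direction, so that a 1.1-fold higher number from compound 2 to compound 3 (0.03 log units; within the scatter) is the expected outcome. Compound 3 is therefore estimated at 9000 nM, likely between 4000 nM and 20000 nM.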

Compound 3, half-maximal inhibitory concentration: 9610 nM
Compound 3: middle estimate off by 1.1-fold (0.03 log units), on the low side; measured number inside the range.
By their numbers in this assay, from the lowest: compounds 2, 3 and 1 (each within the scatter of the next).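

Among the compounds shown here, this is the first step that changes only one place: in this assay, 2-methylphenyl in place of 3-chlorophenyl on an oxygen on an aromatic ring gives a 1.1-fold higher number from compound 2 to compound 3 (0.06 log units; within the scatter). Both groups are six-membered aromatic rings of carbon only, without hydrogen-bond donors or acceptors, and at this position the chlorine-bearing ring and the methyl-bearing ring cannot be told apart in this assay. Nothing available explains this result or ties it to any property of the two groups.

From the compounds shown here alone, it remains open whether a phenyl ring bearing an amine or a carboxylic acid, or a saturated ring such as cyclohexyl, on this oxygen would move the number beyond the scatter. Going by these compounds, whether any change here can give a clearly stronger inhibitor also remains open.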